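Adding 4-Methylphenyl to the Ring Nitrogen of Compound 1

This account rests on a few compounds, and the source may have more. Where it says the series, first, only, none or still open, it means among the compounds named here.

Compounds that slow the growth of cancer cells are often compared by how little of each is needed to do so. Among the compounds with values here, in a functional assay on MCF7 cells (Homo sapiens) for antiproliferative activity, read by MTT assay, with a stated time of 72 h (a lower number here means a stronger inhibitor, a higher number a weaker inhibitor), compound 1 `O=C1COc2ccc(-c3cccc(NS(=O)(=O)c4ccc(F)cc4)c3)cc2N1` gives 18300 nM, the only exact number so far. Compound 2 `Cc1ccc(N2C(=O)COc3ccc(-c4cnc5ccccc5c4)cc32)cc1` is reported only as a limit, > 40000 nM.

The next compound to be tested is compound 3 `Cc1ccc(N2C(=O)COc3ccc(-c4cccc(NS(=O)(=O)c5ccc(F)cc5)c4)cc32)cc1`. It keeps the core of compound 1 and differs in one place: 4-methylphenyl in place of hydrogen on an amide-type nitrogen in a ring. A hydrogen gives way to 4-methylphenyl on an amide-type nitrogen in a ring, so a small atom is replaced by a whole aromatic ring.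

Within the data shown here, no measured pair of compounds shows what this change does in this assay, so there is little to guide a prediction. The best expectation is therefore no shift beyond the usual scatter, with a slight lean towards stronger inhibition and real uncertainty in both directions. The estimated change is a 1.7-fold lower number from compound 1 to compound 3 (0.22 log units; within the scatter). For compound 3, the expected value is 11000 nM, with an estimated range from 2500 nM to 40000 nM.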

Compound 3, half-maximal inhibitory concentration: 32100 nM
Estimate against measurement, compound 3: 2.9-fold (0.47 log units) below; the measured number falls inside the stated range.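

In this assay, putting 4-methylphenyl in place of hydrogen on the amide-type nitrogen gives a 1.8-fold higher number from compound 1 to compound 3 (0.24 log units; within the scatter). Within the data shown here, this is the first reading of this position: the amide hydrogen can give way to a whole aromatic ring without a shift beyond the usual scatter, at least in this one pair, so the compound keeps a measurable number and the hydrogen does not appear to be essential for the activity read here. Compound 2, which carries the same 4-methylphenyl, is reported only as a limit of the assay and not as a number: the limit of > 40000 nM in this assay, at which 1 of the 3 values shown sits.

The compounds shown leave open what a plain methyl, a phenyl without its methyl group, or a longer chain ending in an amine would do on this same nitrogen. Among these compounds, with only one step at this position, it also remains open whether any group placed here can move the number beyond the scatter, in either direction.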